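The compounds below may be only part of what the source reports. "The series", "measured", "known", "first", "only" and "open" are said of these compounds alone.

Compound 3 `COc1cc(-c2cc(-c3cc(C(C)C)c(O)cc3C)[nH]c(=O)c2C#N)ccc1O` is tested in a functional assay for inhibition, tested at 100 ug/mL (on this read-out higher numbers stand for a stronger effect at the one concentration tested and lower numbers for a weaker effect), where compound 3 gives 44%. On the numbers shown this is the smallest of three: compound 1 `COc1ccc(-c2cc(-c3cc(C(C)C)c(O)cc3C)[nH]c(=O)c2C#N)c(OC)c1` gives 58% and compound 2 `COc1ccc(-c2cc(-c3cc(C(C)C)c(O)cc3C)[nH]c(=O)c2C#N)cc1` gives 54%. The step of a number 14 percentage points lower from compound 1 to compound 3 (beyond the scatter) lies beyond the scatter, whereas a number 10 percentage points lower from compound 2 to compound 3 (within the scatter) and a number 4 percentage points lower from compound 1 to compound 2 (within the scatter) stay within it. Compound 4 `Cc1cc(O)c(C(C)C)cc1-c1cc(-c2ccc(N(C)C)cc2)c(C#N)c(=O)[nH]1` differs from compound 3 in one place: 4-(dimethylamino)phenyl in place of 4-hydroxy-3-methoxyphenyl on an aromatic carbon. The two measured steps into compound 3 both exchange the phenyl group at the same place on the shared core, so they bear on this change, but neither involves a dimethylamino group. Because compound 2 with a single methoxy gives 54%, a small rise is expected, a number 8 percentage points higher from compound 3 to compound 4 (within the scatter). Compound 4 is estimated at 52%, from 35% to 68%.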

Compound 4, a percentage reported as inhibition, at one concentration (the size of the read-out at that concentration, not a potency): 68%
The estimate for compound 4 lay 16 percentage points below the measured number; the range from low to high includes it.
By their numbers in this assay, from the lowest: compounds 3, 2, 1 and 4 (each within the scatter of the next, the first and the last beyond it).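

In this assay, swapping the methoxy of 4-methoxyphenyl for dimethylamino at this position gives a clear gain (a number 14 percentage points higher from compound 2 to compound 4 (beyond the scatter)), and the gain over 4-hydroxy-3-methoxyphenyl is larger (a number 24 percentage points higher from compound 3 to compound 4 (beyond the scatter)). The 2,4-dimethoxyphenyl group cannot be separated from 4-(dimethylamino)phenyl (a number 10 percentage points higher from compound 1 to compound 4 (within the scatter)), so a nitrogen group on this ring is not shown to outperform every oxygen pattern. No measurement available here explains these differences. From the compounds shown here alone, whether a methylamino group or a morpholine ring in place of dimethylamino would hold this level remains open.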